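Swapping a Methylphenyl Arm for a Formylphenyl One

The compounds below may be only part of what the source reports. "The series", "measured", "known", "first", "only" and "open" are said of these compounds alone.

Of the compounds shown here, three built on one shared core have been tested in a functional assay on SNB-75 cells (Homo sapiens) for inhibition, read by sulforhodamine B assay, with a stated time of 48 h, tested at 10 uM; on this read-out lower numbers stand for less inhibition and higher numbers for more inhibition at the one concentration tested (going by the name of the read-out). Compound 1 `O=Cc1ccc(-c2cn3ccnc3c(-c3ccc4ncn(C5CCCCC5)c4c3)n2)cc1` gives 21.4%. Compound 2 `CCc1ccc(-c2cn3ccnc3c(-c3ccc4ncn(Cc5ccccc5)c4c3)n2)cc1` gives 29.3%, and compound 3 `Cc1cccc(-c2cn3ccnc3c(-c3ccc4ncn(Cc5ccccc5)c4c3)n2)c1` gives 21.7%. Compound 3 stands second highest of these three numbers, with compound 1 nearest and compound 2 furthest, but both gaps lie within the scatter of repeated measurements, so no real ordering can be read from them. Within the data shown here, the single measured step between neighbouring structures, a number 7.6 percentage points lower from compound 2 to compound 3 (within the scatter), is likewise within the scatter.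

Compound 4 `O=Cc1ccc(-c2cn3ccnc3c(-c3ccc4ncn(Cc5ccccc5)c4c3)n2)cc1` has not yet been measured. It differs from compound 3 by 4-formylphenyl in place of 3-methylphenyl on an aromatic carbon. Among the measured compounds shown here, no measured step matches this exact change. For the measured compounds named here, the one step that exists, a number 7.6 percentage points lower from compound 2 to compound 3 (within the scatter), concerns the same position and shows that exchanging one ring substituent there for another left this assay essentially unchanged. The same 4-formylphenyl that enters in compound 4 is already carried by compound 1, which gives 21.4%, a value within the scatter of compound 3. The step of a number 0.3 percentage points higher from compound 3 to compound 4 (within the scatter) is therefore expected to stay within the scatter, in no particular direction. Compound 4 is estimated at 22%, within a range of 12% to 32%, because compound 1 gives 21.4%.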

Compound 4, a percentage reported as inhibition, at one concentration (the size of the read-out at that concentration, not a potency): 21.4%
Compound 4: the middle estimate sits 0.6 percentage points above what was measured; the range from low to high includes it.
By their numbers in this assay, from the lowest: compounds 1, 4, 3 and 2 (each within the scatter of the next).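

In this assay, the reading comes out a number 0.3 percentage points lower from compound 3 to compound 4 (within the scatter) when 4-formylphenyl replaces 3-methylphenyl, so a group with a hydrogen-bond acceptor can sit on this aromatic carbon without any shift beyond the scatter. Formyl in place of ethyl, the closer comparison at the same ring, gives a number 7.9 percentage points lower from compound 2 to compound 4 (within the scatter) and so adds no clear effect either. With 4-formylphenyl held fixed, benzyl in place of cyclohexyl on the aromatic nitrogen gives no change at the digits printed from compound 1 to compound 4 (within the scatter) and provides a direct comparison at that second place, where the readings also stay together.

No measurement at hand explains why these readings stay so close. Going by these compounds, whether an amine or a carboxylic acid on the phenyl ring, or a longer chain on the aromatic nitrogen, would move the reading beyond the scatter remains open.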